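Sulfamoyl to carbamoyl: cytotoxicity in cultured cells

The compounds below may be only part of what the source reports. "The series", "measured", "known", "first", "only" and "open" are said of these compounds alone.

Compound 1 `Cn1ccc2c(Nc3ccc(OC(F)(F)F)cc3)ncnc21` is one of two members measured in an ADME assay on BaF3 cells (Mus musculus) for cytotoxicity; a higher number here means that more compound is needed for the effect, a lower number that less compound is needed. In this assay compound 1 gives > 10000 nM, a limit of the assay rather than a number. Compound 2 `NS(=O)(=O)c1ccc(-c2cc(Nc3ccc(OC(F)(F)F)cc3)ncn2)cc1` in this assay gives > 10000 nM, again a limit. Compound 2 thus stands together with the other value shown at the limit of > 10000 nM in this assay, at which 2 of the 2 values shown sit. Compound 3 `NC(=O)c1ccc(-c2cc(Nc3ccc(OC(F)(F)F)cc3)ncn2)cc1` differs from compound 2 by carbamoyl in place of sulfamoyl on an aromatic carbon. Within the data shown here, no measured step covers this change. No shift beyond the usual scatter is expected, so the step that the limit leaves unreadable from compound 2 to compound 3 is only an estimate. Compound 3 is expected to give 15000 nM, with a range from 7000 nM to 40000 nM, most likely again reported as a limit.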

Compound 3, half-maximal effective concentration: > 10000 nM
Compound 3: no number, only a limit (the forecaster's own chance of this, stated with the estimate: 80%); the middle value does not contradict the limit.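

Compound 2 and compound 3 both sit at a limit of this assay, so no step between them can be read: the limit of > 10000 nM in this assay, at which 3 of the 3 values shown sit.

From the compounds shown here alone, whether carbamoyl in place of sulfamoyl shifts the half-maximal effective concentration at all stays open.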